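This account rests on a few compounds, and the source may have more. Where it says the series, first, only, none or still open, it means among the compounds named here.

Within the data shown here, the three compounds measured so far share a chromone core carrying a basic side chain through an aryl ether oxygen. Compound 1 `O=c1cc(-c2ccccc2)oc2cccc(OCCCCN3CCC(O)CC3)c12` gives 177 nM in an assay on isolated protein (Cavia porcellus) with Sigma non-opioid intracellular receptor 1 (Homo sapiens) as the target, read by radioligand binding; on this read-out higher numbers stand for weaker inhibition and lower numbers for stronger inhibition. Compound 2 `CN(C)CCCCCCCCCCOc1ccc2oc(-c3ccccc3)cc(=O)c2c1` gives 341 nM in this assay, the highest of the three numbers; against compound 1 the difference lies within the scatter, so no order between these two can be read. Compound 3 `O=c1cc(C2CCCC2)oc2ccc(OCCCCCCN3CCCCC3)cc12` gives 38 nM in this assay, and its gap to compound 2 lies beyond the scatter.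

Compound 4 `NCCCCCCOc1ccc2oc(-c3ccccc3)cc(=O)c2c1` has not yet been measured in this assay. It differs from compound 2 by one change: amino in place of 4-(dimethylamino)butyl on a saturated chain carbon, six bonds along the chain from an oxygen on an aromatic ring. The side chain thus ends in a nitrogen bearing no carbon substituents, and the chain between that nitrogen and the aryl ether oxygen is shorter than in compound 2.

The account expects compound 4 to come out weaker than compound 2 in this assay, with the step from compound 2 to compound 4 estimated at a 2.3-fold higher number from compound 2 to compound 4 (0.37 log units; beyond the scatter), a change beyond the scatter but not a large one. Compound 4 is therefore estimated at 800 nM in this assay, with a plausible range from 200 nM to 3000 nM.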

Compound 4, half-maximal inhibitory concentration: 3700 nM
For compound 4 the middle estimate is 4.6-fold (0.67 log units) below the measured one; measured number above the stated range.
By their numbers in this assay, from the lowest: compound 3; then compounds 1 and 2 (each within the scatter of the next); then compound 4.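

Among these compounds, the first single-place comparison in this set shows that the side chain is not a tolerant site in this assay: amino in place of 4-(dimethylamino)butyl on a saturated chain carbon, six bonds along the chain from an oxygen on an aromatic ring, gives an 11-fold higher number from compound 2 to compound 4 (1.04 log units; beyond the scatter), a large step beyond the scatter. The earlier compounds shown here could show no such effect, since each differs from the others in more than one place, and the gap between compound 2 and compound 3 cannot be assigned to any single change. This one change both removes the two methyl groups on the nitrogen and shortens the chain, and no data here explain the loss or say which part of the change carries it.

The compounds shown therefore leave open how much of the step belongs to each part: a dimethylamino group on the shorter chain of compound 4, or an amino group on the longer chain of compound 2, would separate the two. Also open, going by these compounds, is where a methylamino group on either chain would fall, and whether a piperidine ring at this point would behave differently on the core of compound 4.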